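The compounds below may be only part of what the source reports. "The series", "measured", "known", "first", "only" and "open" are said of these compounds alone.

Series notes

- compound 1 `C=C1C=CC(=O)[C@@H]2[C@H](Cc3ccc(OCOC)cc3)CC[C@H]12`: 77.4 nM
- compound 2 `C=C1C=CC(=O)[C@@H]2[C@H](Cc3ccccc3)CC[C@H]12`: 237 nM

In a functional assay on A-375 cells (Homo sapiens) for antiproliferative activity, with a stated time of 72 h (a higher number here means a weaker inhibitor, a lower number a stronger inhibitor), compound 2 gives 237 nM, the higher of the two numbers and so the weaker of the pair. The next compound is compound 3 `C=C1C=CC(=O)[C@@H]2[C@H](Cc3ccc(O)cc3)CC[C@H]12`, with the change hydroxy in place of hydrogen on an aromatic carbon, para to a large group. For the measured compounds named here, only one measured step bears on this change. Removing the methoxymethoxy group gave a 3.1-fold higher number from compound 1 to compound 2 (0.49 log units; beyond the scatter), a modest step beyond the scatter. That step suggests that a substituent on this aromatic carbon may lower the number, though a single pair is thin evidence and hydroxy has not yet been tested. A smaller step toward a lower number is therefore expected in this assay, and it may not clear the scatter. The expected change is a 1.9-fold lower number from compound 2 to compound 3 (0.28 log units; within the scatter). For compound 3 the estimated value is 125 nM, with an expected range of 45 nM to 340 nM.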

Compound 3, half-maximal inhibitory concentration: 30.8 nM
Compound 3: the middle estimate sits 4.1-fold (0.61 log units) above what was measured; the measured number lies below the stated range.
By their numbers in this assay, from the lowest: compound 3; then compound 1; then compound 2.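

In this assay, placing a substituent on this aromatic carbon, para to a large group, lowers the number in a second case: hydroxy gives a 7.7-fold lower number from compound 2 to compound 3 (0.89 log units; beyond the scatter), so the effect is no longer tied to the methoxymethoxy group alone. The identity of the substituent also matters, as removing the methyl-bearing cap from the oxygen gives a 2.5-fold lower number from compound 1 to compound 3 (0.40 log units; beyond the scatter), which places the free hydroxy ahead of its methoxymethoxy counterpart by more than the scatter. Nothing measured here accounts for this order.

As far as these compounds go, whether the oxygen itself is needed stays open, and an amine or a fluorine atom at this carbon would test that directly. A simple methoxy group would show whether the lower number needs the free hydroxy hydrogen or only a smaller group than methoxymethoxy.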